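The source may hold more compounds than are shown below. What is called first, only, known or untested is meant among the compounds shown, and "the series" means these compounds.

Compounds measured so far:

Compound 1 `CC(C)N(Cc1cccc(OCCCCCC(=O)O)c1)C(=O)c1ccc(-c2cccc3ccccc23)cc1` — in an ADME assay on HEK293 cells (Homo sapiens) for cytotoxicity, read by CellTiter-Glo and resazurin assay, with a stated time of 72 h (a lower number here means that less compound is needed, a higher number that more compound is needed for the effect), compound 1 gives > 26000 nM, which is a limit of the assay rather than a number.
Compound 2 `CC(C)N(Cc1cccc(OCCCCCC(=O)O)c1)C(=O)c1ccc(-c2ccoc2)cc1` — in this assay compound 2 gives > 26000 nM, again a limit.
Compound 3 `CC(C)N(Cc1cccc(OCCCCCC(=O)O)c1)C(=O)c1ccc(-c2ccsc2)cc1` — in this assay compound 3 gives > 26000 nM, also a limit.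

Compound 3 therefore stands where the other two stand: at the limit (the limit of > 26000 nM in this assay, at which 3 of the 3 values shown sit), with no number of its own. The steps among the three, a step that the two limits leave unreadable from compound 1 to compound 2, a step that the two limits leave unreadable from compound 1 to compound 3 and a step that the two limits leave unreadable from compound 2 to compound 3, cannot be read in size, since each end is a limit.

Compound 4 `CC(C)N(Cc1cccc(OCCCCCC(=O)O)c1)C(=O)c1ccc(-c2ccc3c(c2)OCCO3)cc1` differs from compound 3 in one place: 2,3-dihydro-1,4-benzodioxin-6-yl in place of thiophen-3-yl on an aromatic carbon. Among the measured compounds shown here, none of the measured steps gives a readable size, so the only guide is that all three compounds sit at the limit regardless of which group occupies this position. On that basis the expected step is a step that the limit leaves unreadable from compound 3 to compound 4, that is, none beyond the scatter, with compound 4 estimated at 30000 nM in this assay, most likely reported again as a limit, within a range of 15000 nM to 60000 nM.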

Compound 4, half-maximal effective concentration: > 21900 nM
Compound 4 gave a limit, no number; the forecaster's own chance of this, stated with the estimate: 85%; the middle value does not contradict the limit.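

Among the compounds shown here, compound 4, like compound 1, compound 2 and compound 3, sits at a limit in this assay rather than at a number, so no step from any of them to compound 4 can be read in size. The compounds shown leave open what concentration of any of the four gives the half-maximal effect, and whether the group on that aromatic carbon alters it.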